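The source may report more compounds than this note shows. Statements on the series, on what has been measured and on what is new or still open speak of the compounds shown alone.

Measured compounds:
- compound 1, `CN(Cc1cccc(C(=O)O)c1)c1ccc(OCc2c(-c3c(Cl)cccc3Cl)noc2C2CC2)nc1C(F)(F)F`, gives 102%
- compound 2, `CN(Cc1ccc(C(=O)O)cc1)c1ccc(OCc2c(-c3c(Cl)cccc3Cl)noc2C2CC2)nc1C(F)(F)F`, gives 109%
- compound 3, `CC(C)c1onc(-c2c(Cl)cccc2Cl)c1COc1cnc(N(C)Cc2ccc(C(=O)O)cc2)c(Cl)c1`, gives 103%

All three were tested in an assay on isolated protein for agonist activity at Bile acid receptor (Homo sapiens), read by FRET; on this read-out lower numbers stand for smaller maximal responses and higher numbers for larger maximal responses. Compound 1 and compound 2 share one core and differ only in one group: 3-carboxyphenyl in place of 4-carboxyphenyl on a saturated chain carbon bound to a nitrogen on an aromatic ring. This change gave a number 7 percentage points lower from compound 2 to compound 1 (within the scatter), so the two compounds behave alike in this assay. Compound 3 has a different core; the difference between the two cores is not broken down here, and the values of compound 2 and compound 3 simply sit close together. In this assay compound 3 gives 103%, close to compound 1 and close to compound 2.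

Compound 4, `CC(C)c1onc(-c2c(Cl)cccc2Cl)c1COc1cnc(N(C)Cc2cccc(C(=O)O)c2)c(Cl)c1`, has not yet been tested. It differs from compound 3 by 3-carboxyphenyl in place of 4-carboxyphenyl on a saturated chain carbon bound to a nitrogen on an aromatic ring, which is the same change that turns compound 2 into compound 1, now made on the core of compound 3. Since the step from compound 2 to compound 1 stayed within the usual scatter, the expectation is that the step from compound 3 to compound 4 will be about as small, a number 5 percentage points lower from compound 3 to compound 4 (within the scatter), because compound 3 starts from 103% and the earlier change gave a number 7 percentage points lower from compound 2 to compound 1 (within the scatter). This rests on a single precedent and on one pair of cores, so it is a guess, not a rule. Compound 4 is therefore expected to give about 98% in this assay, with a likely range from 84% to 112%.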

Compound 4, largest response reached (reported as efficacy), in percent of the reference or control that the assay uses: 105%
For compound 4 the middle estimate is 7 percentage points below the measured one; the measured number falls inside the stated range.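

In this assay, putting 3-carboxyphenyl in place of 4-carboxyphenyl on the second core gave a number 2 percentage points higher from compound 3 to compound 4 (within the scatter), a step too small to separate from the ordinary variation between repeated measurements. Set beside the earlier case, the two steps cannot be told apart, so on these two cores the change carries over as one with no readable effect on the largest response: the same change on two cores in this assay, a number 7 percentage points lower (within the scatter) from compound 2 to compound 1 and a number 2 percentage points higher (within the scatter) from compound 3 to compound 4, 9 percentage points apart, within the scatter of two such steps This does not show that the change would behave the same way on a third core, since two cores are too few for a rule, and it says nothing about how much compound is needed to reach that response, because the read-out records only the maximal response.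

All the compounds shown carry either 3-carboxyphenyl or 4-carboxyphenyl at this place, so it remains open how 2-carboxyphenyl, or a phenyl ring bearing an amide or a tetrazole instead of the carboxylic acid, would behave. From the compounds shown here alone, a longer chain in place of the single saturated carbon that joins the carboxyphenyl group to the nitrogen also remains open, as does whether either of the two cores would respond differently to such a group.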